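The source may report more compounds than this note shows. Statements on the series, on what has been measured and on what is new or still open speak of the compounds shown alone.

Measured in a functional assay on MCF7 cells (Homo sapiens) for antiproliferative activity, read by MTT assay, with a stated time of 72 h; on this read-out lower numbers stand for stronger inhibition and higher numbers for weaker inhibition:
Compound 1 (`O=C1COc2ccc(-c3cccc(NS(=O)(=O)c4ccc(F)cc4)c3)cc2N1`): 18300 nM
Compound 2 (`CC(C)N1C(=O)COc2ccc(-c3cccc(NS(=O)(=O)c4ccc(F)cc4)c3)cc21`): 26000 nM
Compound 3 (`O=C1COc2ccc(-c3cccc(NS(=O)(=O)c4ccc(F)cc4)c3)cc2N1C1CC1`): > 40000 nM (a limit, not a number)

Compound 3 has no exact value and sits at the limit of > 40000 nM in this assay, at which 1 of the 3 values shown sits.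

Compound 4 (`COc1ccc(N2C(=O)COc3ccc(-c4cccc(NS(=O)(=O)c5ccc(F)cc5)c4)cc32)cc1`) carries 4-methoxyphenyl in place of cyclopropyl on an amide-type nitrogen in a ring.

The closest guides are the other changes at this nitrogen. Isopropyl in place of hydrogen gave a 1.4-fold higher number from compound 1 to compound 2 (0.15 log units; within the scatter), cyclopropyl in place of hydrogen gave an at least 2.1-fold higher number from compound 1 to compound 3 (0.33 log units; beyond the scatter), and cyclopropyl in place of isopropyl gave an at least 1.5-fold higher number from compound 2 to compound 3 (0.18 log units; that floor lies within the scatter). None of these steps went to a lower number, and no aromatic ring at this nitrogen has been measured.

Resting on compound 2 (26000 nM), a value near the top of the measured range is expected in this assay, with no step beyond the scatter. Compound 4 may possibly give only a limit again. The expected step is (an at least 1.4-fold lower number from compound 3 to compound 4 (0.15 log units; that floor lies within the scatter)). For compound 4 the estimate is 28000 nM, with an expected range from 12000 nM to 50000 nM.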

Compound 4, half-maximal inhibitory concentration: 32400 nM
Compound 4: middle estimate off by 1.2-fold (0.06 log units), on the low side; low and high end bracket the measured number.
By their numbers in this assay, from the lowest: compounds 1, 2 and 4 (each within the scatter of the next). At a limit, above all of these: compound 3.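

In this assay, for the compounds shown here, putting an aromatic ring on the amide-type nitrogen in a ring, which no earlier compound had, leaves the number within the scatter of both the isopropyl and the hydrogen compounds: a 1.2-fold higher number from compound 2 to compound 4 (0.10 log units; within the scatter) and a 1.8-fold higher number from compound 1 to compound 4 (0.25 log units; within the scatter). So at this nitrogen, 4-methoxyphenyl, hydrogen and isopropyl cannot be told apart, and an added aromatic ring brings no clear gain or loss. Compared with cyclopropyl, the change gives an at least 1.2-fold lower number from compound 3 to compound 4 (0.09 log units; that floor lies within the scatter), and compound 3 has only a limit, so the true size of this step stays unknown: the limit of > 40000 nM in this assay, at which 1 of the 4 values shown sits.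

Going by these compounds, it remains open whether phenyl without the methoxy group would behave like 4-methoxyphenyl. On these data alone, it is also open whether an amine or a carboxylic acid on a longer chain at this nitrogen would give a clearly lower number than compound 1.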